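Swapping the sulfonamide arm for a tolyl group

A few compounds are considered here, and "the series" means these few. Any claim that something is new, unique, unknown or untested is made for them only; others in the source may bear on it.

This account concerns a series of compounds sharing one core and differing only in the group on an aromatic carbon of the five-membered aromatic ring with 3 nitrogen. In a functional assay on HCT-116 cells (Homo sapiens) for antiproliferative activity, read by MTT assay, with a stated time of 72 h (on this read-out higher numbers stand for weaker inhibition and lower numbers for stronger inhibition), compound 1 `O=C1O[C@H]([C@@H](O)Cn2cc(-c3ccc(Br)cc3)nn2)C(OCc2ccccc2)=C1OCc1ccccc1` gives 9420 nM, compound 2 `O=C1O[C@H]([C@@H](O)Cn2cc(-c3cccc(O)c3)nn2)C(OCc2ccccc2)=C1OCc1ccccc1` gives 42900 nM, and compound 3 `O=C1O[C@H]([C@@H](O)Cn2cc(CNS(=O)(=O)c3ccc(Cl)cc3)nn2)C(OCc2ccccc2)=C1OCc1ccccc1` gives 8380 nM. Compound 3 and compound 1 sit within the scatter of each other, as shown by a 1.1-fold lower number from compound 1 to compound 3 (0.05 log units; within the scatter), whereas compound 2 stands apart: a 5.1-fold lower number from compound 2 to compound 3 (0.71 log units; beyond the scatter) and a 4.6-fold higher number from compound 1 to compound 2 (0.66 log units; beyond the scatter).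

Compound 4 `Cc1ccc(-c2cn(C[C@H](O)[C@H]3OC(=O)C(OCc4ccccc4)=C3OCc3ccccc3)nn2)cc1` is the next member, not yet measured. It differs from compound 3 by 4-methylphenyl in place of (((4-chlorophenyl)sulfonyl)amino)methyl on an aromatic carbon. For the measured compounds named here, two measured steps bear on this change. The exchange of an aryl group for the sulfonamide-bearing arm changed little, as a 1.1-fold lower number from compound 1 to compound 3 (0.05 log units; within the scatter) shows, so an aryl group can return without a large shift in this assay. Going by the values given here, the one clearly larger step, a 4.6-fold higher number from compound 1 to compound 2 (0.66 log units; beyond the scatter), involved a 3-hydroxyphenyl group, which compound 4 does not carry. The expected step is therefore small, within the scatter, in either direction: a 1.1-fold higher number from compound 3 to compound 4 (0.05 log units; within the scatter). Compound 4 is accordingly estimated at 9500 nM in this assay, with a range from 4000 nM to 25000 nM.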

Compound 4, half-maximal inhibitory concentration: > 100000 nM
Compound 4 was reported as a limit (the forecaster's own chance of this, stated with the estimate: 5%); middle value at least 10-fold (1.02 log units) away from the limit.
By their numbers in this assay, from the lowest: compounds 3 and 1 (each within the scatter of the next); then compound 2. At a limit, above all of these: compound 4.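

Compound 4 is reported in this assay only as a limit, > 100000 nM, and not as a number: the limit of > 100000 nM in this assay, at which 1 of the 4 values shown sits. This shows that the place on the five-membered aromatic ring with 3 nitrogen does not accept aryl groups in general, for methyl in place of bromo, a single small exchange on the phenyl group, gives an at least 10-fold higher number from compound 1 to compound 4 (1.02 log units; beyond the scatter). The agreement within the scatter between the 4-bromophenyl and sulfonamide-bearing compounds therefore did not extend to 4-methylphenyl, which gives an at least 11-fold higher number from compound 3 to compound 4 (1.07 log units; beyond the scatter) against the sulfonamide-bearing arm and an at least 2.3-fold higher number from compound 2 to compound 4 (0.36 log units; beyond the scatter) against 3-hydroxyphenyl, so the compound with the highest measured number no longer marks the top of the series.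

The compounds shown leave open how an unsubstituted phenyl, a 4-methoxyphenyl or a 4-aminophenyl group would read at this place, and so whether the bromo group of compound 1 is what sets it apart from compound 4. On these data alone, the full size of all three steps also stays open, as each of them ends at a limit.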